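Ortho-methoxy benzamide in place of para-methyl benzamide

This account rests on a few compounds, and the source may have more. Where it says the series, first, only, none or still open, it means among the compounds named here.

Measured compounds:
- compound 1, `CCN1CCN(c2cc(C)c3cc(NC(=O)c4ccc(C)cc4)ccc3n2)CC1`: 11400 nM
- compound 2, `Cc1cc(N(C)C)nc2ccc(NC(=O)c3ccc(Cl)c(Cl)c3)cc12`: > 50000 nM
- compound 3, `Cc1cc(NCCN2CCCC2)nc2ccc(NC(=O)c3ccc(Cl)c(Cl)c3)cc12`: 9530 nM

In a functional assay on SK-BR-3 cells (Homo sapiens) for antiproliferative activity, read by MTT assay, with a stated time of 72 h (on this read-out lower numbers stand for stronger inhibition and higher numbers for weaker inhibition), compound 1 gives 11400 nM. Going by the values given here, compound 3 gives 9530 nM, a number that lies within the usual scatter of the one for compound 1, so the two cannot be ordered. For compound 2 the assay reports only a limit, > 50000 nM (the limit of > 50000 nM in this assay, at which 1 of the 3 values shown sits). Among the compounds with values here, the one step that can be measured here, an at least 5.2-fold lower number from compound 2 to compound 3 (0.71 log units; beyond the scatter), concerns the amine group on the core and not the benzamide, so it does not bear on the change now considered.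

Compound 4, `CCN1CCN(c2cc(C)c3cc(NC(=O)c4ccccc4OC)ccc3n2)CC1`, differs from compound 1 in one place: 2-methoxyphenyl in place of 4-methylphenyl on a carbonyl carbon. No measured pair among these compounds changes the aryl group of the amide, so nothing here shows in which direction such a change moves the read-out. The step is therefore expected to stay within the scatter, a 1.2-fold higher number from compound 1 to compound 4 (0.09 log units; within the scatter), with wide uncertainty. Compound 4 is estimated at 14000 nM, expected to fall between 4000 nM and 50000 nM.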

Compound 4, half-maximal inhibitory concentration: 15700 nM
The estimate for compound 4 lay 1.1-fold (0.05 log units) below the measured number; the measured number falls inside the stated range.
By their numbers in this assay, from the lowest: compounds 3, 1 and 4 (each within the scatter of the next). At a limit, above all of these: compound 2.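

In this assay, going by these compounds alone, the amide aryl group now has a measured pair for the first time: 2-methoxyphenyl in place of 4-methylphenyl on a carbonyl carbon gives a 1.4-fold higher number from compound 1 to compound 4 (0.14 log units; within the scatter), so compound 1 and compound 4 cannot be ordered. The earlier step concerned only the amine group on the core, whereas this one shows that this exchange at the amide, which adds an oxygen and 1 hydrogen-bond acceptor, produces no difference that can be told from the scatter. Nothing measured here offers a reason for this outcome. Still open, as far as these compounds go, is whether the same holds for other groups on this carbonyl carbon, such as 4-methoxyphenyl, 2-methylphenyl or a pyridine ring. From the compounds shown here alone, it also remains unknown whether an aryl exchange of this kind would read the same alongside the amine group of compound 3.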